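Swapping the Aryl Group on the Triazole Nitrogen

The source may report more compounds than this note shows. Statements on the series, on what has been measured and on what is new or still open speak of the compounds shown alone.

Compound 1 `N#CC1=C(N)Oc2c(c3nc4ccccc4nc3c3ccccc23)C12C(=O)N(Cc1cnnn1-c1cc(Cl)ccc1Cl)c1ccccc12` reaches only the assay limit in an ADME assay on L02 cells (Homo sapiens) for antiproliferative activity, read by MTT assay, with a stated time of 48 h (a higher number here means a weaker inhibitor, a lower number a stronger inhibitor), giving > 50000 nM. Among the compounds with values here, compound 2 `N#CC1=C(N)Oc2c(N)cc3nc4ccccc4nc3c2C12C(=O)N(Cc1cnnn1-c1ccccc1Br)c1ccccc12` holds the sole measured number here, giving 29200 nM in this assay, while the remaining value sits at the limit of > 50000 nM in this assay, at which 1 of the 2 values shown sits. Compound 3 `N#CC1=C(N)Oc2c(N)cc3nc4ccccc4nc3c2C12C(=O)N(Cc1cnnn1-c1ccc([N+](=O)[O-])cc1[N+](=O)[O-])c1ccccc12` differs from compound 2 in one place: 2,4-dinitrophenyl in place of 2-bromophenyl on an aromatic nitrogen. Within the data shown here, no step between two measured compounds is available to gauge this change, so the expected shift from compound 2 to compound 3 is a 1.0-fold higher number from compound 2 to compound 3 (0.01 log units; within the scatter), within the scatter in either direction. Compound 3 is therefore estimated at 30000 nM, with a range from 12000 nM to 50000 nM.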

Compound 3, half-maximal inhibitory concentration: 22800 nM
Beside the measured number, compound 3's estimate is 1.3-fold (0.12 log units) above it, within the range that was stated.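

This first step at this position, in this assay, reads (a 1.3-fold lower number from compound 2 to compound 3 (0.11 log units; within the scatter)). The swap to 2,4-dinitrophenyl on the aromatic nitrogen brings in 4 hydrogen-bond acceptors and a larger group, yet the number stays within the scatter of that for 2-bromophenyl. Nothing measured here offers a reason for this result.

From the compounds shown here alone, whether an amine or a carboxylic acid on this phenyl ring, or a longer alkyl chain in its place, would move the number beyond the scatter stays open. So does whether the same swap would behave alike on the core of compound 1.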